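The source may hold more compounds than are shown below. What is called first, only, known or untested is meant among the compounds shown, and "the series" means these compounds.

Working notes on the series. Compound 1 `CC(=O)Nc1ccc(-n2nncc2CN2C(=O)C3(C(C#N)=C(N)Oc4c3c3nc5ccccc5nc3c3ccccc43)c3ccccc32)cc1` and compound 2 `Cc1ccc(C)c(-n2nncc2CN2C(=O)C3(C(C#N)=C(N)Oc4c3c3nc5ccccc5nc3c3ccccc43)c3ccccc32)c1` were run in a functional assay on MCF7 cells (Homo sapiens) for antiproliferative activity, read by MTT assay, with a stated time of 48 h; on this read-out lower numbers stand for stronger inhibition and higher numbers for weaker inhibition. Compound 1 reports only a limit, > 50000 nM. Compound 2 likewise reports only a limit, > 50000 nM. The step that the two limits leave unreadable from compound 1 to compound 2 is therefore not readable. Compound 3 `COc1ccc(-n2nncc2CN2C(=O)C3(C(C#N)=C(N)Oc4c(N)cc5nc6ccccc6nc5c43)c3ccccc32)cc1` also reports only a limit in this assay, > 50000 nM. Compound 3 thus sits at the limit of > 50000 nM in this assay, at which 3 of the 3 values shown sit, and nothing separates it from the other two. Compound 4 `N#CC1=C(N)Oc2c(N)cc3nc4ccccc4nc3c2C12C(=O)N(Cc1cnnn1-c1c(Cl)cc(Cl)cc1Cl)c1ccccc12` is not yet measured; it differs from compound 3 by 2,4,6-trichlorophenyl in place of 4-methoxyphenyl on an aromatic nitrogen. No measured step bears on this change, since the only step shown is unreadable and every exchange of the group on the aromatic nitrogen so far has left the value at the limit. The expected outcome for compound 4 in this assay is 60000 nM, within 20000 nM to 200000 nM. The expected step that the limit leaves unreadable from compound 3 to compound 4 is thus estimated as none beyond the scatter, with a strong chance that only a limit is reported again.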

Compound 4, half-maximal inhibitory concentration: 37800 nM
Estimate against measurement, compound 4: 1.6-fold (0.20 log units) above; low and high end bracket the measured number.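

In this assay, the group on the aromatic nitrogen gives an at least 1.3-fold lower number from compound 3 to compound 4 (0.12 log units; that floor lies within the scatter). Going by these compounds alone, this is the first exchange at this position to give a number rather than a limit, though compound 3 reports only a limit, so the true size of the step stays unknown. Compound 4 alone among the four has a measured number: the limit of > 50000 nM in this assay, at which 3 of the 4 values shown sit.

As far as these compounds go, it remains open whether the three chlorine atoms are all needed for a readable number. Also open, from the compounds shown here alone, is how a single chlorine or an amine on this phenyl ring would read.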